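Trading chloro for isobutyl in an antiproliferative series

A few compounds are considered here, and "the series" means these few. Any claim that something is new, unique, unknown or untested is made for them only; others in the source may bear on it.

Measured in a functional assay on MCF7 cells (Homo sapiens) for antiproliferative activity, read by sulforhodamine B assay, with a stated time of 48 h; on this read-out lower numbers stand for stronger inhibition and higher numbers for weaker inhibition:
Compound 1 `CCCCCCCc1ccc(NS(=O)(=O)c2ccc(N3CCNC3=O)cc2)cc1`: > 1000 nM
Compound 2 `O=C1NCCN1c1ccc(S(=O)(=O)Nc2ccc(Cl)cc2)cc1`: 170 nM

The entry for compound 1, > 1000 nM, is a limit and not a number. Going by the values given here, that leaves compound 2, at 170 nM, with the only actual number. Compound 3 `CC(C)Cc1ccc(NS(=O)(=O)c2ccc(N3CCNC3=O)cc2)cc1` departs from compound 2 by isobutyl in place of chloro on an aromatic carbon, with isobutyl in place of chloro on an aromatic carbon. Among the compounds with values here, the one measured step bearing on this change is an at least 5.8-fold lower number from compound 1 to compound 2 (0.76 log units; beyond the scatter), where chloro replaced heptyl. From the compounds shown here alone, one end of that step is the limit of > 1000 nM in this assay, at which 1 of the 2 values shown sits, so its full size is unknown. Going by an at least 5.8-fold lower number from compound 1 to compound 2 (0.76 log units; beyond the scatter), a move back from chloro to a carbon chain is expected to raise the number in this assay, though perhaps less steeply for the isobutyl chain. The expected step is a 2.6-fold higher number from compound 2 to compound 3 (0.42 log units; beyond the scatter). For compound 3 the estimate is 450 nM, with an expected range of 150 nM to 1500 nM.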

Compound 3, half-maximal inhibitory concentration: > 1000 nM
Compound 3: only a limit was reported (the forecaster's own chance of this, stated with the estimate: 30%); at least 2.2-fold (0.34 log units) between middle value and limit.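

Until now the loss in this assay could be tied to the heptyl chain alone, but the much smaller isobutyl chain also gives an at least 5.8-fold higher number from compound 2 to compound 3 (0.76 log units; beyond the scatter). Among the compounds shown, chloro is therefore the only group on this aromatic carbon, para to a large group, that gives a number and not a limit, while both carbon chains end at the limit. The step from compound 1 to compound 3 cannot be read, so the two chains cannot be ranked: the limit of > 1000 nM in this assay, at which 2 of the 3 values shown sit.

Whether a methyl or ethyl group would keep the activity of chloro remains open, so the compounds shown do not fix the chain length at which activity is lost. Equally open, from the compounds shown here alone, is whether fluoro, bromo or methoxy at this position would match or improve on chloro.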